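The compounds below may be only part of what the source reports. "The series", "measured", "known", "first", "only" and "open" are said of these compounds alone.

Measured compounds:
compound 1 `COC(=O)[C@H]1c2cc(/C=C/C(=O)NCCCCNC(=N)N)ccc2O[C@@H]1c1ccc(O)cc1` with 2160000 nM
compound 2 `N=C(N)NCCCCNC(=O)/C=C/c1ccc2c(c1)[C@@H](C(=O)NCCCCNC(=N)N)[C@@H](c1ccc(O)cc1)O2` with 2440000 nM

The study covers two measured compounds and one that awaits measurement. In an assay on isolated protein (Salivary gland) for displacement of a labelled ligand from Alpha-1A adrenergic receptor (Rattus norvegicus) (a lower number here means a stronger inhibitor, a higher number a weaker inhibitor), compound 1 gives 2160000 nM and compound 2 gives 2440000 nM. Compound 2 carries the highest of the two numbers, but its nearest neighbour is compound 1, whose number is lower by an amount that sits within the scatter, so no order can be read between them.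

Compound 3 `N=C(N)NCCCCNC(=O)/C=C/c1ccc2c(c1)[C@H](C(=O)NCCCCNC(=N)N)[C@@H](c1ccc(O)cc1)O2` is the next member. It differs from compound 2 in this way: the two compounds have the same atoms and bonds; at least one stereo element is drawn with a configuration in one of them and without one in the other: 1 of 5 stereo elements differ; a stereocentre at a saturated ring carbon is drawn R in compound 2 and S in compound 3. Going by the values given here, no step between two measured compounds is available to size this change; both measured values lie in the same very weak region. Compound 3 is therefore expected to stay near compound 2, with a step of a 1.0-fold lower number from compound 2 to compound 3 (0.01 log units; within the scatter) that could fall either way but is not expected to exceed the scatter. Compound 3 is estimated at 2400000 nM in this assay, within 800000 nM to 7000000 nM.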

Compound 3, half-maximal inhibitory concentration: 310000 nM
Beside the measured number, compound 3's estimate is 7.7-fold (0.89 log units) above it; the measured number lies below the stated range.
By their numbers in this assay, from the lowest: compound 3; then compounds 1 and 2 (each within the scatter of the next).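

Until now, nothing in this series had moved the number in this assay beyond the scatter, but a single change of configuration at a saturated ring carbon does so, with a 7.9-fold lower number from compound 2 to compound 3 (0.90 log units; beyond the scatter), while atoms and bonds stay the same. The step of a 7.0-fold lower number from compound 1 to compound 3 (0.84 log units; beyond the scatter) is of similar size, and since compounds 1 and 2 lie within the scatter of each other, the group of 9 heavy atoms on a carbonyl carbon goes with a lower number only when that carbon is drawn S, not when it is drawn R. The first step carries a caution about how the structures are drawn: the fact that one of compounds 2 and 3 is drawn with a defined configuration and the other without, at the place where they differ

Still open, from the compounds shown here alone, is whether the same configuration change would lower the number with the group of 2 heavy atoms in place. Also open, going by these compounds, is how a carboxylic acid or a longer chain on that carbonyl carbon would fare.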